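The compounds below may be only part of what the source reports. "The series", "measured", "known", "first", "only" and "open" are said of these compounds alone.

Measured compounds:
- compound 1, `Cc1ccc(C2C(C#N)=C(N)N(c3ccc(S(N)(=O)=O)cc3)C3=C2C(=O)CCC3)cc1`: 30%
- compound 2, `N#CC1=C(N)N(c2ccc(S(N)(=O)=O)cc2)C2=C(C(=O)CCC2)C1c1ccc(O)cc1`: 90%
- compound 3, `N#CC1=C(N)N(c2ccc(S(N)(=O)=O)cc2)C2=C(C(=O)CCC2)C1c1ccc(Cl)cc1Cl`: 40%

In a functional assay on Ehrlich cells (Mus musculus) for antiproliferative activity, read by trypan blue exclusion, with a stated time of 2 h, tested at 10 ug/mL (a higher number here means a stronger effect of the compound at the concentration tested, a lower number a weaker effect), compound 3 gives 40%. Against compound 1 the gap is a number 10 percentage points higher from compound 1 to compound 3 (within the scatter), so the two are not told apart; against compound 2 the gap is a number 50 percentage points lower from compound 2 to compound 3 (beyond the scatter), and only that separation is real.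

Compound 4, `Cc1ccoc1C1C(C#N)=C(N)N(c2ccc(S(N)(=O)=O)cc2)C2=C1C(=O)CCC2`, is the next step. 3-methylfuran-2-yl in place of 2,4-dichlorophenyl on a saturated ring carbon

Two measured steps change the group on the same saturated ring carbon. The step of a number 10 percentage points higher from compound 1 to compound 3 (within the scatter) was small, while the step of a number 50 percentage points lower from compound 2 to compound 3 (beyond the scatter) was large and came with the loss of a hydroxy group. The entering 3-methylfuran-2-yl is a five-membered aromatic ring with one hetero atom, a kind of group not seen among the measured compounds, so neither step maps directly onto this change. With no hydroxy group involved and the other aryl swap within the scatter, no step beyond the scatter is expected in this assay, in either direction; the uncertainty is wide.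

Compound 4 is therefore estimated at 45%, within 20% to 75%, which means an expected step of a number 5 percentage points higher from compound 3 to compound 4 (within the scatter).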

Compound 4, a percentage reported as activity, at one concentration (the size of the read-out at that concentration, not a potency): 2%
For compound 4 the middle estimate is 43 percentage points above the measured one; measured number below the stated range.
By their numbers in this assay, from the lowest: compound 4; then compounds 1 and 3 (each within the scatter of the next); then compound 2.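

Until now, only the loss of the hydroxy group had moved the number in this assay beyond the scatter. Now a number 38 percentage points lower from compound 3 to compound 4 (beyond the scatter) and a number 28 percentage points lower from compound 1 to compound 4 (beyond the scatter) show that the group on this saturated ring carbon also matters among groups without a hydroxy. The gap of a number 88 percentage points lower from compound 2 to compound 4 (beyond the scatter) is the largest step seen at this position, and no measurement at hand explains the drop in compound 4.

With a single five-membered ring shown, it remains open whether the low number goes with the ring and its oxygen or with the methyl group on it, which furan-2-yl or thiophen-2-yl would help separate. From the compounds shown here alone, it is also open whether the high number of compound 2 needs the hydroxy group itself, a question that 4-methoxyphenyl or 4-aminophenyl would address.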